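The source may report more compounds than this note shows. Statements on the series, on what has been measured and on what is new or still open speak of the compounds shown alone.

Among the measured compounds shown here, in a physicochemical assay for solubility, read by nephelometry (a higher number here means a more soluble compound, a lower number a less soluble compound), compound 1 (`CC1(C)C(=O)N(c2ccc(SC(F)(F)F)cc2)C(=O)N1Cc1ccnc(C(=O)O)c1`) gives 0.142 ug/mL as the only actual number so far. Compound 2 (`CN(C)c1cc(CN2C(=O)N(c3ccc(SC(F)(F)F)cc3)C(=O)C2(C)C)ccn1`) reads < 0.022 ug/mL which is a limit of the assay. Compound 3 (`CNC(=O)c1cc(CN2C(=O)N(c3ccc(SC(F)(F)F)cc3)C(=O)C2(C)C)ccn1`) has methylamino in place of hydroxy on a carbonyl carbon, carboxy to methylcarbamoyl (methylamino in place of hydroxy on a carbonyl carbon). For the measured compounds named here, the one measured step bearing on this also removes the carboxy (an at least 6.4-fold lower number from compound 1 to compound 2 (0.80 log units; beyond the scatter)) so a lower number is expected in this assay again. The carbonyl stays, so a smaller step is expected (a 2.8-fold lower number from compound 1 to compound 3 (0.45 log units; beyond the scatter)). Compound 3 is estimated at 0.05 ug/mL (range 0.02 ug/mL to 0.15 ug/mL).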

Compound 3, solubility: < 0.023 ug/mL
Compound 3: only a limit was reported; the forecaster's own chance of this, stated with the estimate: 25%; at least 2.1-fold (0.33 log units) between middle value and limit.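

On a carbonyl carbon, methylamino in place of hydroxy gives an at least 6.1-fold lower number from compound 1 to compound 3 (0.79 log units; beyond the scatter) in this assay, so keeping the carbonyl does not by itself hold the reading up. Compound 3 gives a limit, not a number: the limit of < 0.023 ug/mL in this assay, at which 1 of the 3 values shown sits. The step between the two compounds at limits cannot be read.

As far as these compounds go, how far the true values of compound 2 and compound 3 lie past their limits stays open. Also open, from the compounds shown here alone, is whether an unsubstituted carboxamide, a methyl ester or a tetrazole in place of the carboxy group gives a measurable number.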